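The source may hold more compounds than are shown below. What is called first, only, known or untested is meant among the compounds shown, and "the series" means these compounds.

In an assay (Rattus norvegicus) for inhibition of Fatty-acid amide hydrolase 1 (Homo sapiens) (a higher number here means a weaker inhibitor, a lower number a stronger inhibitor), three compounds have been measured: compound 1 `NS(=O)(=O)c1ccc(-c2cnc(C(=O)CCCCCCc3ccccc3)o2)cc1` gives 10 nM, compound 2 `NC(=O)c1ccc(-c2cnc(C(=O)CCCCCCc3ccccc3)o2)cc1` gives 10 nM, and compound 3 `O=C(CCCCCCc1ccccc1)c1ncc(-c2ccc(C(=O)C(F)(F)F)cc2)o1` gives 65 nM.

Compound 2 stands level with compound 1, the two together giving the lowest numbers, since no change at the digits printed from compound 1 to compound 2 (within the scatter). Compound 3 lies further off: a 6.5-fold higher number from compound 2 to compound 3 (0.81 log units; beyond the scatter), a modest step.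

Compound 4 `O=C(CCCCCCc1ccccc1)c1ncc(-c2cncnc2)o1` has not yet been measured. It differs from compound 2 by pyrimidin-5-yl in place of 4-carbamoylphenyl on an aromatic carbon. Going by the values given here, no measured step touches this part of the shared core; the two known steps only swap the group on the phenyl ring, and show that carbamoyl and sulfamoyl give the lowest numbers while the trifluoromethyl-bearing group raises the number modestly. Removing the whole 4-carbamoylphenyl is a larger change than either, so a weaker inhibitor is expected, probably by more than the modest step seen. Compound 4 is expected to give about 100 nM, between 25 nM and 400 nM. The expected step is a 10-fold higher number from compound 2 to compound 4 (1.00 log units; beyond the scatter).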

Compound 4, inhibition constant: 22 nM
Beside the measured number, compound 4's estimate is 4.5-fold (0.66 log units) above it, outside the stated range (below it).
By their numbers in this assay, from the lowest: compounds 1 and 2 (each within the scatter of the next); then compound 4; then compound 3.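

At this place on the shared core, in this assay, the whole 4-carbamoylphenyl can give way to pyrimidin-5-yl at only a modest cost (a 2.2-fold higher number from compound 2 to compound 4 (0.34 log units; beyond the scatter)). The earlier steps shown here only swapped the group on the phenyl ring; this one shows that the inhibitor keeps most of its strength with a smaller group that has no hydrogen-bond donor. Nothing available explains this step. Still open, from the compounds shown here alone, is how a plain phenyl or a pyridine ring would compare here, and whether an amine on the pyrimidine would change the number.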